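Nitro for methyl on the aryl piperazine of a dithiocarbamate

A few compounds are considered here, and "the series" means these few. Any claim that something is new, unique, unknown or untested is made for them only; others in the source may bear on it.

Compound 1 `Cc1ccc(N2CCN(C(=S)SCc3ccc4nc(N)nc(N)c4c3)CC2)cc1` carries a 4-methylphenyl on the amine nitrogen of its piperazine ring. In a functional assay on HCT-116 cells (Homo sapiens) for antiproliferative activity, read by MTT assay, with a stated time of 72 h (a lower number here means a stronger inhibitor, a higher number a weaker inhibitor), compound 1 gives 5510 nM. Its closest neighbour, compound 2 `Nc1nc(N)c2cc(CSC(=S)N3CCN(c4ccccc4Cl)CC3)ccc2n1`, gives 5490 nM in this assay, so the two values lie within the scatter of each other; the step of a 1.0-fold lower number from compound 1 to compound 2 (0.00 log units; within the scatter) swapped the 2-chlorophenyl for the 4-methylphenyl without moving the number. Compound 3 `Nc1nc(N)c2cc(CSC(=S)N3CCN(c4ccccc4F)CC3)ccc2n1` belongs to the same series, but in this assay compound 3 stands only as "not determined" (no result reported), so it contributes no number.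

Compound 4 `Nc1nc(N)c2cc(CSC(=S)N3CCN(c4ccc([N+](=O)[O-])cc4)CC3)ccc2n1` differs from compound 1 by nitro in place of methyl on an aromatic carbon. Going by the values given here, the only measured step that bears on a change of the aryl group on the piperazine nitrogen is the one from compound 1 to compound 2, and it stayed within the scatter. The expectation for compound 4 is therefore a step of a 1.0-fold lower number from compound 1 to compound 4 (0.00 log units; within the scatter), none beyond the scatter. Compound 4 is estimated at 5500 nM, with a range from 2500 nM to 12000 nM.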

Compound 4, half-maximal inhibitory concentration: 4680 nM
Compound 4: the middle estimate sits 1.2-fold (0.07 log units) above what was measured; low and high end bracket the measured number.
By their numbers in this assay, from the lowest: compounds 4, 2 and 1 (each within the scatter of the next).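

In this assay the nitro group on the aromatic carbon para to a large group gives a 1.2-fold lower number from compound 1 to compound 4 (0.07 log units; within the scatter) and so shows that a change at this single position, with two hydrogen-bond acceptors entering where methyl has none, leaves the value within the scatter. Set against the 2-chlorophenyl, the 4-nitrophenyl gives a 1.2-fold lower number from compound 2 to compound 4 (0.07 log units; within the scatter) and makes it a third aryl group, so that compound 1, compound 2 and compound 4 all lie within the scatter of one another. No evidence on the cause of this flat result is at hand.

The compounds shown leave open whether any group on this aromatic carbon, such as an amine or a carboxylic acid, moves the number beyond the scatter. They also leave open whether replacing the aryl group on the piperazine nitrogen with a longer chain would do so.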